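Lengthening the amine arms of compound 3

A few compounds are considered here, and "the series" means these few. Any claim that something is new, unique, unknown or untested is made for them only; others in the source may bear on it.

In a functional assay on MCF7 cells (Homo sapiens) for antiproliferative activity (a higher number here means a weaker inhibitor, a lower number a stronger inhibitor), compound 1 `CC(C)=CCc1cc(C(=O)Nc2cc3ccc(OCCC4CCCCN4)c(C)c3oc2=O)ccc1O` gives 710 nM, while compound 3 `CCN(CC)CCCOc1ccc2cc(NC(=O)c3ccc(O)c(CC=C(C)C)c3)c(=O)oc2c1C` gives 6390 nM, the higher of these two numbers, with a 9.0-fold higher number from compound 1 to compound 3 (0.95 log units; beyond the scatter). Compound 2 `CC(C)=CCc1cc(C(=O)Nc2cc3ccc(OCCCN4CCCCC4)c(C)c3oc2=O)ccc1O` reads > 50000 nM, which is a limit of the assay. Compound 4 `CCCN(CCC)CCCOc1ccc2cc(NC(=O)c3ccc(O)c(CC=C(C)C)c3)c(=O)oc2c1C` carries dipropylamino in place of diethylamino on a saturated chain carbon, three bonds along the chain from an oxygen on an aromatic ring. Within the data shown here, the closest precedent is an at least 7.8-fold lower number from compound 2 to compound 3 (0.89 log units; beyond the scatter), the only measured change of amine on this same chain, so a small shift towards a higher number is expected. The expected change is a 1.3-fold higher number from compound 3 to compound 4 (0.10 log units; within the scatter). Compound 4 is estimated at 8000 nM, with an expected range of 2000 nM to 35000 nM.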

Compound 4, half-maximal inhibitory concentration: > 50000 nM
Compound 4: only a limit was reported; the forecaster's own chance of this, stated with the estimate: 15%; middle value at least 6.2-fold (0.79 log units) away from the limit.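

Lengthening the arms from diethylamino to dipropylamino is not a neutral change at this position, giving an at least 7.8-fold higher number from compound 3 to compound 4 (0.89 log units; beyond the scatter), and the gap to the piperidin-2-yl compound widens, with an at least 70-fold higher number from compound 1 to compound 4 (1.84 log units; beyond the scatter). The value of compound 4, > 50000 nM, is a limit of the assay. The step between compound 2 and compound 4 cannot be read, because both values sit at the same limit: the limit of > 50000 nM in this assay, at which 2 of the 4 values shown sit.

Still open, on these data alone, is whether dimethylamino or a pyrrolidine ring at the end of this propyl chain would give a lower number than diethylamino does.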